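The source may report more compounds than this note shows. Statements on the series, on what has been measured and on what is new or still open speak of the compounds shown alone.

Measured so far:
- compound 1, `N/C(=N\NC(=S)N1CCCC1)c1ccc(F)cn1`: 73% in a functional assay on MCF7 cells (Homo sapiens) for cytotoxicity, read by MTT assay, with a stated time of 72 h, tested at 100 uM; on this read-out lower numbers stand for less inhibition of growth and higher numbers for more inhibition of growth at the one concentration tested
- compound 2, `N/C(=N\NC(=S)N1CCSCC1)c1ccccn1`: 72.4% in this assay

Compound 2 gives the lower of the two numbers, but the value of compound 1 sits within the usual scatter of it, so the two measured compounds cannot be told apart on growth inhibition.

Compound 3, `N/C(=N\NC(=S)N1CCSCC1)c1ccc(F)cn1`, has not been measured. It differs from compound 2 by fluoro in place of hydrogen on an aromatic carbon. Compound 1 already carries this fluoro, on a different amine at the thiourea, and its number stands level with that of compound 2. Among the compounds with values here, no single-change step between measured compounds is available, so the size of the change cannot be read off directly; on the two numbers at hand, no step beyond the scatter is expected in either direction.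

Compound 3 is therefore estimated at 74%, with a range of 62% to 86%. The expected step of a number 1.6 percentage points higher from compound 2 to compound 3 (within the scatter) is small and within the scatter.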

Compound 3, percent growth inhibition at one concentration: 65.7%
Estimate against measurement, compound 3: 8.3 percentage points above, and the stated range covers the measured number.
By their numbers in this assay, from the lowest: compounds 3, 2 and 1 (each within the scatter of the next).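

Fluoro in place of hydrogen on the aromatic carbon, two atoms from the ring nitrogen and para to a large group, can now be read directly in this assay: it gives a number 6.7 percentage points lower from compound 2 to compound 3 (within the scatter). With the fluoro held constant, thiomorpholin-4-yl in place of pyrrolidin-1-yl on the thiocarbonyl carbon gives a number 7.3 percentage points lower from compound 1 to compound 3 (within the scatter), so neither single change separates from the scatter in this assay. No measurement bears on the reason for these numbers.

Still open, from the compounds shown here alone, is whether chloro, methoxy or an amino group on this aromatic carbon, or morpholin-4-yl or piperidin-1-yl on the thiocarbonyl carbon, would give a step beyond the scatter. Also open, going by these compounds, is how the three compounds compare at other concentrations, as single-concentration numbers give no concentration-response.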